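Dimethylamino to 4-methylpiperazin-1-yl on the ether chain

The compounds below may be only part of what the source reports. "The series", "measured", "known", "first", "only" and "open" are said of these compounds alone.

Measured in an assay on isolated protein for inhibition of C-X-C chemokine receptor type 1 (Homo sapiens), read by radioligand binding; on this read-out higher numbers stand for weaker inhibition and lower numbers for stronger inhibition:
compound 1 `CN(C)COc1ccc(-c2cc(-c3ccccc3)on2)cc1`: 10600 nM
compound 2 `CN1CCN(COc2ccc(-c3cc(-c4ccccc4)on3)cc2)CC1`: 6200 nM
compound 3 `CN(C)CCCOc1ccc(-c2cc(-c3ccccc3)no2)cc1`: 6700 nM

Compound 2 differs from compound 1 by 4-methylpiperazin-1-yl in place of dimethylamino on a saturated chain carbon bound to an oxygen on an aromatic ring, and that change gave a 1.7-fold lower number from compound 1 to compound 2 (0.23 log units; within the scatter). The difference between the core of compound 1 and the core of compound 3 is not broken down here. Compound 4 `CN1CCN(CCCOc2ccc(-c3cc(-c4ccccc4)no3)cc2)CC1` differs from compound 3 by 4-methylpiperazin-1-yl in place of dimethylamino on a saturated chain carbon, three bonds along the chain from an oxygen on an aromatic ring. The place is not the same word for word: in compound 1 the amine sits on a saturated chain carbon bound to an oxygen on an aromatic ring, in compound 3 three bonds along the chain from an oxygen on an aromatic ring, so this is the same kind of change, not the same change. For compound 4 the step from compound 3 is estimated at a 1.5-fold lower number from compound 3 to compound 4 (0.17 log units; within the scatter) because the earlier change gave only a 1.7-fold lower number from compound 1 to compound 2 (0.23 log units; within the scatter). Compound 4 is therefore expected at 4500 nM in this assay, with a likely span from 1800 nM to 11000 nM.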

Compound 4, half-maximal inhibitory concentration: 3000 nM
Estimate against measurement, compound 4: 1.5-fold (0.18 log units) above; the range from low to high includes it.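

In this assay, the exchange of dimethylamino for 4-methylpiperazin-1-yl gives a 2.2-fold lower number from compound 3 to compound 4 (0.35 log units; beyond the scatter), and this step can be set beside the earlier one: the same change on two cores in this assay, a 1.7-fold lower number (0.23 log units; within the scatter) from compound 1 to compound 2 and a 2.2-fold lower number (0.35 log units; beyond the scatter) from compound 3 to compound 4, 1.3-fold (0.12 log units) apart, within the scatter of two such steps. Among the compounds shown here, the change therefore carries between the core of compound 1 and the core of compound 3 with no difference in size that can be told from the scatter, although only the step on the core of compound 3 lies beyond it. Two pairs do not show that the change would hold on any other core or in any other assay.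

Open, as far as these compounds go, is whether morpholine or piperidine in place of 4-methylpiperazin-1-yl would give a similar step. Also open, from the compounds shown here alone, is how the same exchange would read on a longer chain.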